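Moving the methyl around the ring: compound 2 to compound 3

The source may hold more compounds than are shown below. What is called first, only, known or untested is meant among the compounds shown, and "the series" means these compounds.

compound 1 `Cc1ccc(NC(=S)NN=C(c2ccccc2)c2ccccc2)cc1`: 28 nM
compound 2 `Cc1cccc(NC(=S)NN=C(c2ccccc2)c2ccccc2)c1`: 14 nM

In a functional assay on HL-60 cells (Homo sapiens) for antiproliferative activity, read by MTT assay, with a stated time of 48 h (a lower number here means a stronger inhibitor, a higher number a weaker inhibitor), compound 1 gives 28 nM and compound 2 gives 14 nM. Compound 2 holds the smaller of the two numbers, yet the step of a 2.0-fold lower number from compound 1 to compound 2 (0.30 log units; within the scatter) lies within the scatter, so the two cannot be told apart. Compound 3 `Cc1ccccc1NC(=S)NN=C(c1ccccc1)c1ccccc1` differs from compound 2 by 2-methylphenyl in place of 3-methylphenyl on an amide-type nitrogen. Among the measured compounds shown here, the only step that bears on this is the one from compound 1 to compound 2, and it was small. A comparably small step, or none beyond the scatter, is therefore expected: a 1.4-fold higher number from compound 2 to compound 3 (0.15 log units; within the scatter). Compound 3 is estimated at 20 nM, with a range from 8 nM to 50 nM.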

Compound 3, half-maximal inhibitory concentration: 34 nM
The estimate for compound 3 lay 1.7-fold (0.23 log units) below the measured number, and the stated range covers the measured number.
By their numbers in this assay, from the lowest: compounds 2, 1 and 3 (each within the scatter of the next, the first and the last beyond it).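

In this assay, among the compounds shown here, where the methyl sits on the ring now shows up for the first time: a 2.4-fold higher number from compound 2 to compound 3 (0.39 log units; beyond the scatter) is the first step here to pass the scatter. By contrast, a 1.2-fold higher number from compound 1 to compound 3 (0.08 log units; within the scatter) does not separate those two, so 2-methylphenyl and 4-methylphenyl cannot be told apart, and only 3-methylphenyl differs from 2-methylphenyl. Nothing available explains this difference. Still open, from the compounds shown here alone, is whether a larger group, such as methoxy or a chlorine atom, or an amine, would change the number at these ring places.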